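Three esters at the assay limit, then the free alcohol

The source may report more compounds than this note shows. Statements on the series, on what has been measured and on what is new or still open speak of the compounds shown alone.

Measured in a functional assay on MOLT-3 cells (Homo sapiens) for cytotoxicity, read by MTT assay, with a stated time of 72 h (on this read-out higher numbers stand for weaker inhibition and lower numbers for stronger inhibition), each value a limit:
- Compound 1 `CCC(=O)OC/C=C(\C)C[C@@H](O)[C@@]1(C)[C@H](C)CC=C2[C@@H]1CCCC2(C)C`: > 30000 nM
- Compound 2 `C/C(=C\COC(=O)c1ccccc1)C[C@@H](O)[C@@]1(C)[C@H](C)CC=C2[C@@H]1CCCC2(C)C`: > 30000 nM
- Compound 3 `COc1ccc(C(=O)OC/C=C(\C)C[C@@H](O)[C@@]2(C)[C@H](C)CC=C3[C@@H]2CCCC3(C)C)cc1`: > 30000 nM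

Compound 3 therefore stands at a limit, not at a number. In compound 4 `C/C(=C\CO)C[C@@H](O)[C@@]1(C)[C@H](C)CC=C2[C@@H]1CCCC2(C)C`, hydrogen takes the place of (4-methoxyphenyl)carbonyl on an oxygen on a saturated carbon: hydrogen in place of (4-methoxyphenyl)carbonyl on an oxygen on a saturated carbon.

The measured steps that bear on this change replace the group on the same carbonyl: a step that the two limits leave unreadable from compound 1 to compound 2, a step that the two limits leave unreadable from compound 1 to compound 3 and a step that the two limits leave unreadable from compound 2 to compound 3. None has a readable size. All that remains is the limit of > 30000 nM in this assay, at which 3 of the 3 values shown sit, so no step beyond the scatter is expected in this assay, in either direction. The expected step is a number no higher from compound 3 to compound 4 (the limit leaves the size open). For compound 4 the estimate is 30000 nM, with an expected range from 12000 nM to 60000 nM.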

Compound 4, half-maximal inhibitory concentration: > 30000 nM
Compound 4 ended at the assay's limit (the forecaster's own chance of this, stated with the estimate: 80%); the middle value sits exactly at the limit.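

The steps from compound 1, compound 2 and compound 3 to compound 4 cannot be read, as each value is a limit, not a number: the limit of > 30000 nM in this assay, at which 4 of the 4 values shown sit.

From the compounds shown here alone, whether the free alcohol, compound 4, truly differs from the three esters in this assay stays open.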